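Benzimidazole for Benzothiazole on a Cytotoxic Ester Side Chain

A few compounds are considered here, and "the series" means these few. Any claim that something is new, unique, unknown or untested is made for them only; others in the source may bear on it.

Compound 1: `C=C1C2=C(C(=O)N1OC)[C@H](OC(=O)CSc1nc3ccccc3s1)[C@@](C)(O)[C@H](CCCCC)O2` — 6300 nM
Compound 2: `C=C1C2=C(C(=O)N1OC)[C@H](O)[C@@](C)(O)[C@H](CCCCC)O2` — 20000 nM

Of the compounds shown here, two sharing one core have been tested in a functional assay on MCF7 cells (Homo sapiens) for cytotoxicity, read by MTT assay, with a stated time of 72 h; on this read-out higher numbers stand for weaker inhibition and lower numbers for stronger inhibition. Compound 1 gives 6300 nM in this assay, the lower of the two numbers; compound 2 gives 20000 nM, and the gap between them lies beyond the usual scatter, so compound 1 is the more potent of the pair measured so far.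

Compound 3, `C=C1C2=C(C(=O)N1OC)[C@H](OC(=O)CSc1nc3ccccc3[nH]1)[C@@](C)(O)[C@H](CCCCC)O2`, has not yet been measured. It differs from compound 1 in one place: 1H-benzimidazol-2-yl in place of 1,3-benzothiazol-2-yl on a sulfur. For the measured compounds named here, no measured pair shows this particular exchange, so there is nothing to anchor its effect, and the change keeps the same ring count and size. The step of a 1.1-fold higher number from compound 1 to compound 3 (0.05 log units; within the scatter) is therefore expected to stay within the scatter, with no clear direction. Compound 3 is estimated to give about 7000 nM in this assay, with a plausible range from 2500 nM to 20000 nM.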

Compound 3, half-maximal inhibitory concentration: 16000 nM
Compound 3: middle estimate off by 2.3-fold (0.36 log units), on the low side, and the stated range covers the measured number.
By their numbers in this assay, from the lowest: compound 1; then compounds 3 and 2 (each within the scatter of the next).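

For the compounds shown here, this exchange gives the first reading on the ring at the end of the ester side chain. In this assay, 1H-benzimidazol-2-yl in place of 1,3-benzothiazol-2-yl on a sulfur gives a 2.5-fold higher number from compound 1 to compound 3 (0.40 log units; beyond the scatter), so this position distinguishes between two groups with the same ring sizes and the same heavy-atom count. The entering group has a nitrogen bearing a hydrogen where the leaving group has a ring sulfur, but nothing available explains why the number rises.

The compounds shown leave open whether the ring hydrogen or the lost ring sulfur accounts for the step, and a benzimidazol-2-yl group carrying a methyl on its ring nitrogen could help separate the two. From the compounds shown here alone, a 1,3-benzoxazol-2-yl group, with an oxygen in the ring, also remains untested among them.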